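A Larger Aromatic Group in Place of 4-Chlorobenzyl

The source may report more compounds than this note shows. Statements on the series, on what has been measured and on what is new or still open speak of the compounds shown alone.

In an assay on a protein complex for binding affinity to integrin alpha-5/beta-1 (Homo sapiens), read by ELISA, with a stated time of 1 h (a lower number here means a stronger inhibitor, a higher number a weaker inhibitor), compound 3 `N=C(N)Nc1cccc(C(=O)NCC(=O)N[C@@H](CC(=O)O)C(=O)NCc2ccc(Cl)cc2)c1` stands as the weakest of the three measured: compound 3 gives 48 nM, while compound 1 `N=C(N)Nc1cccc(C(=O)NCC(=O)N[C@@H](CC(=O)O)C(=O)Nc2cccc3ccccc23)c1` gives 22 nM and compound 2 `C[C@H](NC(=O)[C@H](CC(=O)O)NC(=O)CNC(=O)c1cccc(NC(=N)N)c1)c1ccccc1` gives 20 nM. Both steps toward compound 3 lie beyond the scatter: a 2.2-fold higher number from compound 1 to compound 3 (0.34 log units; beyond the scatter) and a 2.4-fold higher number from compound 2 to compound 3 (0.38 log units; beyond the scatter). Compound 4 `N=C(N)Nc1cccc(C(=O)NCC(=O)N[C@@H](CC(=O)O)C(=O)NCc2cccc(-c3ccccc3)c2)c1` alters the same end of the molecule: 3-phenylphenyl in place of 4-chlorophenyl on a saturated chain carbon bound to an amide-type nitrogen. Those two steps show the 4-chlorobenzyl of compound 3 giving higher numbers than either the naphthalen-1-yl of compound 1 or the 1-phenylethyl of compound 2, so a group of two aromatic rings is expected to move the number back down. Compound 4 is therefore expected to show a 1.7-fold lower number from compound 3 to compound 4 (0.23 log units; within the scatter). Compound 4 is estimated at 28 nM, with an expected range from 10 nM to 80 nM.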

Compound 4, half-maximal inhibitory concentration: 18 nM
Estimate against measurement, compound 4: 1.6-fold (0.19 log units) above, and the stated range covers the measured number.
By their numbers in this assay, from the lowest: compounds 4, 2 and 1 (each within the scatter of the next); then compound 3.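

In this assay the change gives a 2.7-fold lower number from compound 3 to compound 4 (0.43 log units; beyond the scatter) and so shows that this place on a saturated chain carbon bound to an amide-type nitrogen accepts a second aromatic ring without a loss in the number. Compound 4 stands within the scatter of compound 1 and compound 2, so the added ring brings no separation from them. No measurement here explains the drop. The chlorine leaves as the phenyl enters, so the step cannot be assigned to either alone. Going by these compounds, how an amine or a carboxylic acid on the added phenyl would read remains open.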